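This account rests on a few compounds, and the source may have more. Where it says the series, first, only, none or still open, it means among the compounds named here.

Working notes on the series. In an ADME assay on BHK-21 cells (Mesocricetus auratus) for cytotoxicity, read by MTT assay (on this read-out higher numbers stand for lower toxicity in this test and lower numbers for higher toxicity in this test), compound 1 (`C/C(=N\NC(N)=S)c1ccc2c(c1)nc(-c1ccc(C(F)(F)F)cc1)n2C1CCCCC1`) gives > 100000 nM, which is a limit and not a number. Compound 2 (`COc1ccc(-c2nc3cc(/C(C)=N/NC(N)=S)ccc3n2C2CCCCC2)cc1`) has no number to stand on, its entry in this assay reading "not determined" (no result reported). The only reference point is the limit of > 100000 nM in this assay, at which 1 of the 2 values shown sits. Compound 3 (`COc1ccc(-c2nc3cc(/C(C)=N/NC(N)=S)ccc3n2C2CCCCC2)c(OC)c1`) follows through (methoxy in place of hydrogen on an aromatic carbon), methoxy in place of hydrogen on an aromatic carbon, or 4-methoxyphenyl to 2,4-dimethoxyphenyl. No measured step sizes this change, so no shift beyond the scatter is expected in this assay, in either direction. For compound 3 the expected value is 90000 nM, with an estimated range of 35000 nM to 100000 nM.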

Compound 3, half-maximal cytotoxic concentration: 17000 nM
The estimate for compound 3 lay 5.3-fold (0.72 log units) above the measured number, and the stated range ends above it.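

In this assay the aryl group on the shared core proves able to move the read-out: 2,4-dimethoxyphenyl in place of 4-(trifluoromethyl)phenyl gives an at least 5.8-fold lower number from compound 1 to compound 3 (0.76 log units; beyond the scatter) in this series. Among the compounds shown here, compound 3, at 17000 nM, supplies the first actual number here. Compound 1 stands at a limit, so the step is a bound and not a full size: the limit of > 100000 nM in this assay, at which 1 of the 3 values shown sits.

Going by these compounds, the step from compound 2 cannot be read, so what the added methoxy does alone stays open. Also open, on these data alone, is how an amine or a carboxylic acid on this phenyl ring would read.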